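A few compounds are considered here, and "the series" means these few. Any claim that something is new, unique, unknown or untested is made for them only; others in the source may bear on it.

The compounds share one core: a sulfonyl group fixed to a ring that holds a sulfonamide nitrogen, with an aromatic ring sitting on the sulfonyl sulfur. Compound 1 `CC1CCN(C2CCN(S(=O)(=O)c3ccccc3Br)CC2)CC1` carries a 2-bromophenyl there. For the measured compounds named here, in a functional assay on DLD-1 cells (Homo sapiens) for antiproliferative activity, read by CellTiter-Glo, with a stated time of 72 h (on this read-out lower numbers stand for stronger inhibition and higher numbers for weaker inhibition), compound 1 gives 3 nM, the lowest of the three numbers measured so far. Compound 2 `CC1CCN(C2CCN(S(=O)(=O)c3ccccc3-c3ccc(C(F)(F)F)cc3)CC2)CC1` gives 122 nM and compound 3 `CC1CCN(C2CCN(S(=O)(=O)c3ccccc3-c3ccc(Cl)cc3)CC2)CC1` gives 202 nM. The step of a 41-fold higher number from compound 1 to compound 2 (1.61 log units; beyond the scatter) and the step of a 67-fold higher number from compound 1 to compound 3 (1.83 log units; beyond the scatter) both show that trading the single bromo for a second aromatic ring weakens inhibition strongly, while a 1.7-fold higher number from compound 2 to compound 3 (0.22 log units; within the scatter) shows that the choice between those two second rings makes no real difference.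

Compound 4 `CC1CCN(C2CCN(S(=O)(=O)c3cc(Cl)cc(Cl)c3)CC2)CC1` makes a different kind of change: 3,5-dichlorophenyl in place of 2-bromophenyl on a sulfonyl sulfur. Going by the values given here, no measured step covers this exact swap, in which one ring with a bromo gives way to one ring with two chloro groups. The measured steps only describe the move to a second aromatic ring; compound 4 keeps a single ring, so a smaller loss than in those steps is expected, though the bromo of compound 1 is gone and some loss seems likely. The estimate for compound 4 is 20 nM, within 4 nM to 150 nM, which means an expected step of a 6.7-fold higher number from compound 1 to compound 4 (0.82 log units; beyond the scatter).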

Compound 4, half-maximal inhibitory concentration: 3400 nM
Beside the measured number, compound 4's estimate is 170-fold (2.23 log units) below it; the whole stated range lies below it.
By their numbers in this assay, from the lowest: compound 1; then compounds 2 and 3 (each within the scatter of the next); then compound 4.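

The earlier steps shown here tied the loss of inhibition to a second aromatic ring, but compound 4 keeps a single aromatic ring on the sulfonyl sulfur and still loses far more in this assay (a 1100-fold higher number from compound 1 to compound 4 (3.05 log units; beyond the scatter)). Keeping one ring is therefore not enough to hold the low number of compound 1: at this position, the exchange of 2-bromophenyl for 3,5-dichlorophenyl alone is enough for that large step, and, read from the lowest number, the printed values place compound 2 (122 nM) and compound 3 (202 nM), which carry the second ring, ahead of compound 4 (3400 nM). Nothing available explains why this swap costs so much.

The swap changes the halogen, the number of halogens and their places on the ring all at once, so these compounds cannot show which of those changes matters. A 2-chlorophenyl or a 3,5-dibromophenyl would begin to separate them, and a methoxy group or an amine on the ring would show whether anything other than a halogen can be tolerated here.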